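Swapping one large group on a shared core

The source may report more compounds than this note shows. Statements on the series, on what has been measured and on what is new or still open speak of the compounds shown alone.

Two compounds with a shared core have been followed in an ADME assay on the whole organism (strain Sprague-Dawley) for pharmacokinetics, with Rattus norvegicus as the target, at a dose of 1 mg/kg by the intravenous route; on this read-out higher numbers stand for fast clearance and lower numbers for slow clearance. Compound 1 (`CNc1ncc2ccc(Oc3cc(C(=O)c4c(-c5ccccc5)n(C)n(-c5ccccc5)c4=O)ccc3N)cc2n1`) gives 16.7 mL/min/kg, and compound 2 (`Cc1ncc2ccc(Oc3c(C)ccc(C(=O)c4c(-c5ccccc5)n(C)n(-c5ccccc5)c4=O)c3N)cc2n1`) gives 36.7 mL/min/kg. Compound 2 thus holds the higher of the two numbers, and the gap between them lies beyond the usual scatter. Compound 3 (`Cc1ccc(C(=O)c2c(-c3ccccc3)n(C)n(-c3ccccc3)c2=O)c(N)c1-c1ccc2nc(C(F)F)sc2c1`) has not yet been measured in this assay. It differs from compound 2 in one place: 2-(difluoromethyl)-1,3-benzothiazol-6-yl in place of (2-methylquinazolin-7-yl)oxy on an aromatic carbon. Here 2-(difluoromethyl)-1,3-benzothiazol-6-yl takes the place of (2-methylquinazolin-7-yl)oxy on an aromatic carbon, ortho to a methyl group and ortho to an amino group. Among the measured compounds shown here, no measured pair shows what such an exchange does, so the expectation rests only on the two values in hand. For the measured compounds named here, with compound 2 at 36.7 mL/min/kg, the higher number so far, a small fall is thought more likely than a rise, though none beyond the scatter is expected. The expected change is a 1.4-fold lower number from compound 2 to compound 3 (0.15 log units; within the scatter). The estimate for compound 3 is 26 mL/min/kg, expected to lie between 11 mL/min/kg and 58 mL/min/kg.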

Compound 3, clearance: 15.7 mL/min/kg
Compound 3: the middle estimate sits 1.7-fold (0.22 log units) above what was measured, and the stated range covers the measured number.
By their numbers in this assay, from the lowest: compounds 3 and 1 (each within the scatter of the next); then compound 2.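

In this assay, the exchange of (2-methylquinazolin-7-yl)oxy for 2-(difluoromethyl)-1,3-benzothiazol-6-yl on the aromatic carbon, ortho to a methyl group and ortho to an amino group, gives a 2.3-fold lower number from compound 2 to compound 3 (0.37 log units; beyond the scatter), the first step read at this position, and it lies beyond the scatter. The leaving and entering groups have the same count of heavy atoms and neither carries a net charge, so clearance at this position responds to the identity of the group even with that count unchanged. Nothing measured here gives a reason for the step.

This single exchange removes the oxygen and the quinazoline ring and brings in sulfur and fluorine together, so the compounds shown cannot tell which of these differences goes with the lower number. Also open, as far as these compounds go, is whether the step would hold with a trifluoromethyl group or an amine in place of the difluoromethyl group on the benzothiazole, and how the same exchange would behave with the substituents on the rest of the shared core changed.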